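Amide Replaces Basic Amine on the Ether Chain

The source may report more compounds than this note shows. Statements on the series, on what has been measured and on what is new or still open speak of the compounds shown alone.

Compound 3 `CN1CCN(CCCCOc2cc(C(=O)N3CCCCc4sccc43)ccc2NC(=O)c2ccccc2-c2ccccc2)CC1` gives 7 nM in an assay on adrenal medulla for inhibition of Vasopressin V2 receptor (Rattus norvegicus), read by radioligand binding (on this read-out lower numbers stand for stronger inhibition and higher numbers for weaker inhibition), the lowest of the three numbers shown. Compound 2 `O=C(Nc1ccc(C(=O)N2CCCN(CCN3CCCC3)c3sccc32)cc1)c1ccccc1-c1ccccc1` gives 10 nM, which lies within the scatter of compound 3, while compound 1 `O=C(Nc1ccc(C(=O)N2CCCN(Cc3ccccc3)c3sccc32)cc1)c1ccccc1-c1ccccc1` gives 70 nM, a gap beyond the scatter. For the measured compounds named here, the single measured step, a 7.0-fold lower number from compound 1 to compound 2 (0.85 log units; beyond the scatter), concerns a different position of the shared core. Compound 4 `CN1CCCN(C(=O)CCCOc2cc(C(=O)N3CCCCc4sccc43)ccc2NC(=O)c2ccccc2-c2ccccc2)CC1` differs from compound 3 by (4-methyl-1,4-diazepan-1-yl)carbonyl in place of (4-methylpiperazin-1-yl)methyl on a saturated chain carbon, three bonds along the chain from an oxygen on an aromatic ring. Going by the values given here, no measured step touches this chain end, so the account has no direct guide. The step of a 2.9-fold higher number from compound 3 to compound 4 (0.46 log units; beyond the scatter) is therefore expected only as a guess toward a somewhat higher number, with wide uncertainty. Compound 4 is estimated at 20 nM, between 5 nM and 80 nM.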

Compound 4, half-maximal inhibitory concentration: 3 nM
Compound 4: middle estimate off by 6.7-fold (0.82 log units), on the high side, and the stated range ends above it.
By their numbers in this assay, from the lowest: compound 4; then compounds 3 and 2 (each within the scatter of the next); then compound 1.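

In this assay, for the compounds shown here, the end of the ether chain accepts a larger change than the earlier compounds showed, with a 2.3-fold lower number from compound 3 to compound 4 (0.37 log units; beyond the scatter) when (4-methyl-1,4-diazepan-1-yl)carbonyl stands in place of (4-methylpiperazin-1-yl)methyl. This single step changes both the ring, from six-membered to seven-membered, and the carbonyl, so it cannot assign the gain to either one. Nothing shown explains the step.

The compounds shown leave open how (4-methylpiperazin-1-yl)carbonyl or (4-methyl-1,4-diazepan-1-yl)methyl would read at this place. They also leave open what a carboxylic acid or a longer chain would give here.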